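The source may hold more compounds than are shown below. What is called first, only, known or untested is meant among the compounds shown, and "the series" means these compounds.

Compound 1 `CCC1(Cc2ccccc2)OS(=O)(=O)C=C1OCc1ccc(Cl)c(Cl)c1` gives >= 20000 nM in an ADME assay on HEL cells (Homo sapiens) for cytotoxicity, with a stated time of 3 days (a lower number here means that less compound is tolerated, a higher number that more compound is tolerated), which is a limit of the assay.
Compound 2 `O=S1(=O)C=C(OCc2ccccc2)C(Cc2ccccc2)(Cc2ccccc2)O1` gives 200000 nM in this assay.
Compound 3 `CCC1(CC)OS(=O)(=O)C=C1OCc1ccccc1` gives > 400000 nM in this assay, also a limit of the assay.

Among the compounds with values here, compound 2 thus holds the only number among the three; the other two are limits. Compound 3 sits at the limit of > 400000 nM in this assay, at which 1 of the 3 values shown sits. Compound 1 sits at the limit of >= 20000 nM in this assay, at which 1 of the 3 values shown sits. The unmeasured compound 4 `CC(C)CC1(Cc2ccccc2)OS(=O)(=O)C=C1OCc1ccccc1` differs from compound 2 by isopropyl in place of phenyl on a saturated chain carbon bound to a saturated ring carbon. Within the data shown here, no step between two measured compounds is known, so the expectation rests on the change alone: a shift toward more compound being tolerated, likely beyond the scatter, is expected, a 1.5-fold higher number from compound 2 to compound 4 (0.18 log units; within the scatter). Compound 4 is therefore estimated at 300000 nM in this assay, between 100000 nM and 700000 nM.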

Compound 4, minimum cytotoxic concentration: >= 80000 nM
Compound 4: a limit, no number; the forecaster's own chance of this, stated with the estimate: 40%; the middle value lies beyond the limit too.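

Within the data shown here, compound 4 gives only a limit of the assay and not a number, so no step from compound 2 to compound 4 can be read. The compounds shown leave open whether isopropyl in place of phenyl shifts the minimum cytotoxic concentration at all, and in which direction.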